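Swapping the aryl group on the benzyl arm: nitro to nitrile

The compounds below may be only part of what the source reports. "The series", "measured", "known", "first", "only" and "open" are said of these compounds alone.

Measured compounds:
Compound 1 `Nc1nc(O)c2c(n1)n(C1OC(CO)[C@@H](O)[C@H]1O)c(=O)n2Cc1ccc(Cl)c(Cl)c1` gives 15% in a functional assay on YAC-1 cells (Mus musculus); on this read-out higher numbers stand for larger maximal responses and lower numbers for smaller maximal responses.
Compound 2 `Nc1nc(O)c2c(n1)n(C1OC(CO)[C@@H](O)[C@H]1O)c(=O)n2Cc1ccc([N+](=O)[O-])cc1` gives 50% in this assay.

Among the compounds with values here, of the two compounds measured so far, compound 2 stands highest in this assay; its nearest neighbour is compound 1, and the single measured step of a number 35 percentage points higher from compound 1 to compound 2 (beyond the scatter) is well beyond the scatter. Both compounds share the same core and differ only in the aryl ring carried on the saturated chain carbon bound to an aromatic nitrogen.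

Compound 3 `N#Cc1cccc(Cn2c(=O)n(C3OC(CO)[C@@H](O)[C@H]3O)c3nc(N)nc(O)c32)c1` keeps that core and changes the same aryl group once more: 3-cyanophenyl in place of 4-nitrophenyl on a saturated chain carbon bound to an aromatic nitrogen. Within the data shown here, the only measured step that bears on this change is the one from compound 1 to compound 2, and it shows that swapping the aryl group at this place can move the maximal response by a large amount. Which direction a third aryl group takes cannot be read from one step; both groups here carry an acceptor, but that is all the data show. A downward step is expected for compound 3, a number 15 percentage points lower from compound 2 to compound 3 (beyond the scatter), with wide uncertainty. Compound 3 is therefore estimated at 35% in this assay, within 10% to 60%.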

Compound 3, largest response reached (reported as maximal response), in percent of the reference or control that the assay uses: 11%
Compound 3: the middle estimate sits 24 percentage points above what was measured, within the range that was stated.
By their numbers in this assay, from the lowest: compounds 3 and 1 (each within the scatter of the next); then compound 2.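

In this assay, moving from 4-nitrophenyl to 3-cyanophenyl on this saturated chain carbon gives a number 39 percentage points lower from compound 2 to compound 3 (beyond the scatter) and so undoes the gain seen earlier. The other new comparison gives a number 4 percentage points lower from compound 1 to compound 3 (within the scatter), so 3-cyanophenyl and 3,4-dichlorophenyl cannot be told apart on this read-out, even though the two rings carry different groups. The first pair alone could not show which aryl group was the unusual one, but with three compounds, 4-nitrophenyl stands apart from the other two, and a large response at this position clearly does not follow from just any aryl swap. Nothing available explains why the 4-nitrophenyl group stands apart.

From the compounds shown here alone, the step from 4-nitrophenyl to 3-cyanophenyl changes both the group and the number in its name, so it remains open whether the nitro group itself or its place on the ring carries the difference, a question that 4-cyanophenyl or 3-nitrophenyl would address. Also open, going by these compounds, is how an amine such as 4-aminophenyl, or a longer chain between the ring and the shared core, would behave here.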